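The source may hold more compounds than are shown below. What is called first, only, known or untested is meant among the compounds shown, and "the series" means these compounds.

Of the compounds shown here, two have been measured in an assay on isolated protein for inhibition of Fatty-acid amide hydrolase 1 (Homo sapiens), read by fluorescence, with a stated time of 30 min; on this read-out higher numbers stand for weaker inhibition and lower numbers for stronger inhibition. Compound 1 `CCOC(=O)c1cc(-c2ccc(OC(=O)NC3CCCCC3)cc2)n(-c2ccccc2)n1` gives 268 nM, and compound 2 `CC(C)NC(=O)c1cc(-c2cccc(OC(=O)NC3CCCCC3)c2)n(-c2ccccc2)n1` gives 232 nM; these two numbers sit within the usual scatter of each other. Compound 3 `O=C(NC1CCCCC1)Oc1cccc(-c2cc(CO)nn2-c2ccccc2)c1` differs from compound 2 in one place: hydroxymethyl in place of isopropylcarbamoyl on an aromatic carbon. Going by the values given here, no measured pair shows a change of this kind, so the size of the step is uncertain; a modest move toward weaker inhibition is expected, namely a 1.7-fold higher number from compound 2 to compound 3 (0.24 log units; within the scatter). Compound 3 is therefore estimated at 400 nM, with a likely range from 150 nM to 1100 nM.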

Compound 3, half-maximal inhibitory concentration: 462 nM
Compound 3: middle estimate off by 1.2-fold (0.06 log units), on the low side, within the range that was stated.
By their numbers in this assay, from the lowest: compounds 2, 1 and 3 (each within the scatter of the next).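

In this assay this change gives a 2.0-fold higher number from compound 2 to compound 3 (0.30 log units; within the scatter) on this aromatic carbon, so a hydroxymethyl of 2 heavy atoms can replace an isopropylcarbamoyl of 6 heavy atoms without a step beyond the scatter. Both groups carry one hydrogen-bond donor and one acceptor, so this pair does not test the loss of either. No measurement here explains the result.

Going by these compounds, whether an amine, a carboxylic acid or a longer chain on this carbon would also stay within the scatter remains open. So does the outcome for a plain methyl group.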